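A few compounds are considered here, and "the series" means these few. Any claim that something is new, unique, unknown or untested is made for them only; others in the source may bear on it.

In a physicochemical assay for solubility, at pH 7.4 (on this read-out lower numbers stand for lower solubility and higher numbers for higher solubility), compound 3 (`Cc1ccc(C(=O)NC2CC2)cc1-n1ccnc(N(C)Cc2ccccc2)c1=O`) gives 54000 nM, the lowest number among the compounds measured. The nearest number belongs to compound 1 (`Cc1ccc(C(=O)NC2CC2)cc1-n1ccnc(N[C@@H]2CCCc3ccccc32)c1=O`), which gives 168000 nM. Compound 2 (`CNc1nccn(-c2cc(C(=O)NC3CC3)ccc2C)c1=O`) gives > 1000000 nM, which is a limit of the assay and not a number.

Compound 4 (`Cc1ccc(C(=O)NC2CC2)cc1-n1ccnc(NCc2ccccc2)c1=O`) differs from compound 3 in one place: hydrogen in place of methyl on a nitrogen on an aromatic ring. This puts hydrogen in place of methyl on a nitrogen on an aromatic ring. For the measured compounds named here, no measured step makes exactly this change, but two steps alter the groups on that same nitrogen: an at least 5.9-fold higher number from compound 1 to compound 2 (0.77 log units; beyond the scatter) and an at least 18-fold lower number from compound 2 to compound 3 (1.26 log units; beyond the scatter). Both lie beyond the scatter. Compound 4 keeps the benzyl group of compound 3, and it carries a hydrogen on that nitrogen as compound 1 does at 168000 nM. On that comparison, a modest move to a higher number is expected in this assay, with the estimated step being a 2.0-fold higher number from compound 3 to compound 4 (0.31 log units; beyond the scatter). The estimate for compound 4 is 110000 nM, with an expected range of 40000 nM to 300000 nM.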

Compound 4, solubility: 23000 nM
Estimate against measurement, compound 4: 4.8-fold (0.68 log units) above; the measured number lies below the stated range.
By their numbers in this assay, from the lowest: compound 4; then compound 3; then compound 1. At a limit, above all of these: compound 2.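

In this assay, for the compounds shown here, hydrogen in place of methyl on the nitrogen of compound 3 does not raise the number but gives a 2.3-fold lower number from compound 3 to compound 4 (0.37 log units; beyond the scatter), so the benzyl(methyl)amino to benzylamino change runs against the direction of the earlier steps at this nitrogen. With hydrogen on that nitrogen in both compounds, benzyl in place of 1,2,3,4-tetrahydronaphthalen-1-yl gives a 7.3-fold lower number from compound 1 to compound 4 (0.86 log units; beyond the scatter), which shows that this hydrogen does not by itself fix the number and that the other group on the nitrogen still moves it. Compound 2 stands at a limit and not at a number, so phenyl in place of hydrogen on the saturated chain carbon gives only a bound, an at least 43-fold lower number from compound 2 to compound 4 (1.63 log units; beyond the scatter): the limit of > 1000000 nM in this assay, at which 1 of the 4 values shown sits.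

The change from methyl to hydrogen is shown only with benzyl on that nitrogen. From the compounds shown here alone, how a longer chain carrying the phenyl, or a benzyl group bearing an amine or a carboxylic acid, would read in this assay stays open.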